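The compounds below may be only part of what the source reports. "The series", "measured", "known", "first", "only" and "open" are said of these compounds alone.

Values so far in a functional assay on HepG2 cells (Homo sapiens) for cytotoxicity, read by MTT assay, with a stated time of 72 h (a higher number here means a weaker inhibitor, a lower number a stronger inhibitor), are as follows
- compound 1 `CC[S+]([O-])CCCCN=C=S` gives 5350 nM
- compound 2 `COc1ccc(C[S+]([O-])CCCCN=C=S)cc1` gives 4620 nM

Compound 1 sits within the usual scatter of compound 2, so the two values cannot be told apart and neither can be ranked above the other. Among the measured compounds shown here, with only this pair measured, the series offers no step between measured compounds to serve as a guide.

The next compound is compound 3 `[O-][S+](CCCCN=C=S)Cc1ccco1`, still to be measured in this assay. Relative to compound 1, furan-2-yl stands in place of methyl on a saturated chain carbon bound to a sulfur (furan-2-yl in place of methyl on a saturated chain carbon bound to a sulfur). For the measured compounds named here, no measured step shows what such a change does here. Going by the values given here, the only guide is the level shared by compound 1 at 5350 nM and compound 2 at 4620 nM, so no shift beyond the scatter is expected, and no direction is favoured. The estimated change is a 1.1-fold lower number from compound 1 to compound 3 (0.05 log units; within the scatter), expected to stay within the scatter. For compound 3 the expected value is 4800 nM, with an estimated range from 2400 nM to 9500 nM.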

Compound 3, half-maximal inhibitory concentration: 3860 nM
The estimate for compound 3 lay 1.2-fold (0.09 log units) above the measured number; measured number inside the range.
By their numbers in this assay, from the lowest: compounds 3, 2 and 1 (each within the scatter of the next).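

In this assay, among the compounds shown here, furan-2-yl in place of methyl on a saturated chain carbon bound to a sulfur gives a 1.4-fold lower number from compound 1 to compound 3 (0.14 log units; within the scatter) as the first measured step at this place. The step exchanges a single carbon for a five-membered aromatic ring with 1 hetero atom, raising the count from 1 to 5 heavy atoms and adding 1 hydrogen-bond acceptor, yet the two numbers cannot be told apart, so this one exchange gives no sign that the place responds to such a change in this assay. No supporting measurement bears on the reason for this result.

On these data alone, whether any group at this place can move the number beyond the scatter remains open, for example an amine, a carboxylic acid or a longer chain in place of methyl. Also open, as far as these compounds go, is whether the ring oxygen of furan-2-yl matters at all, which thiophen-2-yl at the same place would address by exchanging that oxygen for sulfur while keeping the five-membered aromatic ring.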